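The compounds below may be only part of what the source reports. "The series", "measured", "known", "first", "only" and "open" are said of these compounds alone.

Compound 1 `COc1ccc(Nc2nc(N)c(C(=O)c3ccccc3OC)s2)cc1` is measured in a functional assay on HeLa cells (Homo sapiens) for antiproliferative activity, read by cell counting, with a stated time of 2 days (on this read-out lower numbers stand for stronger inhibition and higher numbers for weaker inhibition), where compound 1 gives 17 nM. Going by the values given here, of the two compounds measured so far, compound 1 gives the lowest number; the nearest is compound 2 `COc1ccccc1C(=O)c1sc(Nc2ccccc2)nc1N`, which in this assay gives 1200 nM. The step between them is a 71-fold higher number from compound 1 to compound 2 (1.85 log units; beyond the scatter). Compound 3 `COc1ccc(Nc2nc(N)c(C(=O)c3cccc(OC)c3)s2)cc1` has not yet been measured. It differs from compound 1 by 3-methoxyphenyl in place of 2-methoxyphenyl on a carbonyl carbon. Among the compounds with values here, the single measured step alters a different part of the molecule, so it does not bear directly on this change, and no step in the data tracks it. Compound 3 is therefore expected to show a step of only a 3.5-fold higher number from compound 1 to compound 3 (0.55 log units; beyond the scatter), toward a somewhat higher number. Compound 3 is estimated to give 60 nM, within a range from 15 nM to 300 nM.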

Compound 3, half-maximal inhibitory concentration: 37 nM
Estimate against measurement, compound 3: 1.6-fold (0.21 log units) above; the range from low to high includes it.
By their numbers in this assay, from the lowest: compound 1; then compound 3; then compound 2.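

In this assay, 3-methoxyphenyl in place of 2-methoxyphenyl on the carbonyl carbon gives a 2.2-fold higher number from compound 1 to compound 3 (0.34 log units; beyond the scatter) and so costs only modestly. The methoxy group on this aryl ketone can therefore change its place with far less effect than the other measured change, hydrogen in place of methoxy on an aromatic carbon, which gives a 71-fold higher number from compound 1 to compound 2 (1.85 log units; beyond the scatter). On these data alone, it remains open how a longer ethoxy chain, a hydroxyl or an amine in place of this methoxy group would read, or whether the group is needed at all. Nothing at hand explains the step.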